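Aryl amine variation in a fused bicyclic pyrrolidine series

The source may report more compounds than this note shows. Statements on the series, on what has been measured and on what is new or still open speak of the compounds shown alone.

Compound 1 `CN1CCC[C@H]1[C@H]1COc2ccc(N)cc2O1` carries an amino group on the aromatic ring of the shared core; in an assay on membranes from HEK293 cells for displacement of a labelled ligand from Neuronal acetylcholine receptor; alpha3/beta4 (Homo sapiens), with a stated time of 5 min (a higher number here means a weaker inhibitor, a lower number a stronger inhibitor), compound 1 gives 180 nM. Its two positional isomers sit well apart from it: compound 2 `CN1CCC[C@H]1[C@H]1COc2cc(N)ccc2O1` gives 8600 nM in this assay, and compound 3 `CN1CCC[C@H]1[C@H]1COc2c(N)cccc2O1` gives 13000 nM. Compound 1 therefore holds the lowest number of the three measured compounds, both gaps to it lying beyond the scatter of repeated measurements, so it is the strongest inhibitor in this set and the reference for further change at the amine.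

Compound 4 `CN(C)c1ccc2c(c1)O[C@@H]([C@@H]1CCCN1C)CO2` is the next member, not yet measured. It differs from compound 1 in one place: dimethylamino in place of amino on an aromatic carbon. Among the measured compounds shown here, no measured pair shows what such a change at this position does; only the relocation of the amine around the ring has been followed. Since compound 4 keeps the position at which compound 1 gives 180 nM and alters only the group itself, a moderate weakening is expected rather than a loss as large as that between compound 1 and compound 2. The expected step from compound 1 to compound 4 in this assay is a 3.3-fold higher number from compound 1 to compound 4 (0.52 log units; beyond the scatter). Compound 4 is estimated at 600 nM in this assay, with a range from 150 nM to 3000 nM.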

Compound 4, inhibition constant: 25000 nM
The estimate for compound 4 lay 42-fold (1.62 log units) below the measured number, and the stated range ends below it.
By their numbers in this assay, from the lowest: compound 1; then compounds 2, 3 and 4 (each within the scatter of the next, the first and the last beyond it).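

In this assay, keeping the position on the aromatic carbon and replacing amino with dimethylamino gives a 140-fold higher number from compound 1 to compound 4 (2.14 log units; beyond the scatter), a large step. Among the compounds shown here, the low number of compound 1 therefore depends on the group itself as well as on where it sits: the earlier compounds followed only the relocation of the amine around the ring, whereas this pair shows that holding the position does not preserve the number. The change goes from 1 hydrogen-bond donor to 0 hydrogen-bond donors and from 1 heavy atom to 3, and no available evidence separates these differences or accounts for the step.

The compounds shown leave open how much of the step is reached with a single added carbon, which a methylamino group at this position would address, and whether a hydroxyl group or an acetamido group could stand in place of amino there. Also open, as far as these compounds go, is what dimethylamino does at the two other ring positions occupied by the amine in compound 2 and compound 3, since only the position held by compound 1 carries it here.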